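From 4-fluorophenyl to 2-chlorophenyl on an aromatic nitrogen

The source may hold more compounds than are shown below. What is called first, only, known or untested is meant among the compounds shown, and "the series" means these compounds.

Compound 1 `O=C1Nc2ccccc2/C1=C/c1ccc(-c2cn(-c3ccccc3Cl)nn2)cc1`: > 20000 nM
Compound 2 `O=C1Nc2ccc(F)cc2/C1=C/c1ccc(-c2cn(-c3cccc(F)c3)nn2)cc1`: 8190 nM
Compound 3 `O=C1Nc2ccc(F)cc2/C1=C/c1ccc(-c2cn(-c3ccc(F)cc3)nn2)cc1`: > 20000 nM
Compound 4 `O=C1Nc2ccc(F)cc2/C1=C/c1ccc(-c2cn(-c3ccccc3Cl)nn2)cc1`: not yet measured

All of these compounds belong to one small series tested in a functional assay on MKN-45 cells (Homo sapiens) for inhibition, read by CCK-8 assay, with a stated time of 24 h; a higher number here means a weaker inhibitor, a lower number a stronger inhibitor. Compound 3 gives > 20000 nM, which is a limit and not a number. Compound 1 gives > 20000 nM, which is also a limit. Within the data shown here, compound 2 gives 8190 nM, the only numerical value so far. The series therefore shows (the limit of > 20000 nM in this assay, at which 2 of the 3 values shown sit).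

Compound 4 differs from compound 3 in a single group: 2-chlorophenyl in place of 4-fluorophenyl on an aromatic nitrogen. It has 2-chlorophenyl in place of 4-fluorophenyl on an aromatic nitrogen of a five-membered aromatic ring with 3 nitrogen.

Among the measured compounds shown here, one measured step concerns a change at this place, an at least 2.4-fold higher number from compound 2 to compound 3 (0.38 log units; beyond the scatter). It shows that the aryl group on this nitrogen can move the result in this assay beyond the scatter, but it involves neither compound 4 nor 2-chlorophenyl. Compound 1 also carries 2-chlorophenyl, and its result in this assay is the limit > 20000 nM.

Only a small shift towards a lower number, or none beyond the scatter, is therefore expected. The expected step is an at least 1.2-fold lower number from compound 3 to compound 4 (0.09 log units; that floor lies within the scatter). For compound 4 the estimated value is 16000 nM, with an expected range of 8000 nM to 30000 nM.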

Compound 4, half-maximal inhibitory concentration: 7540 nM
Compound 4: middle estimate off by 2.1-fold (0.33 log units), on the high side; the whole stated range lies above it.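

In this assay, the aryl group on this nitrogen turns out to matter in more than one way: 2-chlorophenyl in place of 4-fluorophenyl gives an at least 2.6-fold lower number from compound 3 to compound 4 (0.42 log units; beyond the scatter), so this change can recover a measurable result where compound 3 had only a limit. The two aryl groups that give numerical values cannot be told apart, with a 1.1-fold lower number from compound 2 to compound 4 (0.04 log units; within the scatter), and so 3-fluorophenyl and 2-chlorophenyl perform alike here on the same core. The outcome also depends on a second place. The 2-chlorophenyl group does not give a numerical value by itself: fluoro in place of hydrogen on an aromatic carbon gives an at least 2.6-fold lower number from compound 1 to compound 4 (0.42 log units; beyond the scatter).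

The true size of the steps from compound 1 and compound 3 remains open, since each rests on a limit rather than a number: the limit of > 20000 nM in this assay, at which 2 of the 4 values shown sit. The compounds shown also leave open whether the halogen or its place on the aryl group accounts for the gap between compound 3 and compound 4, and how an amine or a methoxy group on that aryl group would read in this assay.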